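A few compounds are considered here, and "the series" means these few. Any claim that something is new, unique, unknown or untested is made for them only; others in the source may bear on it.

Measured so far:

Compound 1, `COc1ccc(CNC(=O)c2cc(Oc3ccc(/C=C/c4ccncc4)cc3)ccn2)cc1`: 19300 nM
Compound 2, `O=C(NC1CCCCC1)c1cc(Oc2ccc(/C=C/c3ccncc3)cc2)ccn1`: 16800 nM

Both compounds were tested in a functional assay on A549 cells (Homo sapiens) for antiproliferative activity, read by CCK-8 assay, with a stated time of 48 h; a lower number here means a stronger inhibitor, a higher number a weaker inhibitor. Compound 1 gives 19300 nM and compound 2 gives 16800 nM. The step of a 1.1-fold lower number from compound 1 to compound 2 (0.06 log units; within the scatter) is too small to mean anything, so on the two numbers shown compound 2 cannot be told apart from compound 1; both sit at weak inhibition.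

Compound 3, `O=C(c1cc(Oc2ccc(/C=C/c3ccncc3)cc2)ccn1)N1CCCC1`, has not yet been measured. It differs from compound 2 in one place: pyrrolidin-1-yl in place of cyclohexylamino on a carbonyl carbon. The amide nitrogen thereby becomes part of the ring and loses its hydrogen-bond donor.

Among the measured compounds shown here, only one measured step bears on this region: a 1.1-fold lower number from compound 1 to compound 2 (0.06 log units; within the scatter), where a very different group on the amide nitrogen left the number essentially unchanged. For the measured compounds named here, no measured step removes the amide hydrogen, so there is no direct precedent for that part of the change. On this thin evidence, compound 3 is expected to stay close to compound 2, with a step of a 1.0-fold higher number from compound 2 to compound 3 (0.01 log units; within the scatter) that is unlikely to exceed the scatter.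

Compound 3 is therefore estimated at 17000 nM, within a range from 7000 nM to 40000 nM.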

Compound 3, half-maximal inhibitory concentration: 18600 nM
The estimate for compound 3 lay 1.1-fold (0.04 log units) below the measured number, within the range that was stated.
By their numbers in this assay, from the lowest: compounds 2, 3 and 1 (each within the scatter of the next).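

In this assay, both a 1.1-fold higher number from compound 2 to compound 3 (0.04 log units; within the scatter) and a 1.0-fold lower number from compound 1 to compound 3 (0.02 log units; within the scatter) leave the numbers indistinguishable, so compounds 1, 2 and 3 cannot be ranked. The earlier pair had only varied the group on an amide nitrogen that kept its hydrogen, whereas pyrrolidin-1-yl has no hydrogen-bond donor and cyclohexylamino has one, so compound 3 adds something new: on this carbonyl carbon, the amide hydrogen is not required for a number at the level of compound 2 in this assay. Nothing available here offers a reason for this flat result.

Going by these compounds, all three compounds are weak inhibitors, so it remains open whether any group on this carbonyl carbon can shift the number beyond the scatter, for example a piperazine ring, a morpholine ring, or a carboxylic acid in place of the amide. Because the three compounds share the same core and differ only in this one place, they also leave open whether changes elsewhere in the core would prove any more telling than those made here.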